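The source may hold more compounds than are shown below. What is called first, only, known or untested is meant among the compounds shown, and "the series" means these compounds.

In a functional assay on HOP-62 cells (Homo sapiens) for inhibition, read by sulforhodamine B assay, with a stated time of 48 h (on this read-out higher numbers stand for weaker inhibition of growth and lower numbers for stronger inhibition of growth), compound 2 `COc1ccc(-c2ccc(-c3ccc(C(=N)N)o3)o2)cc1` gives 1500 nM, and compound 1 `N=C(N)c1ccc(-c2ccc(-c3cc(Cl)cc(Cl)c3)s2)s1` gives 1760 nM; the two values lie within the scatter of each other, so no order between them can be claimed. Compound 3 `N=C(N)c1ccc(-c2ccc(-c3ccc(Cl)cc3)o2)o1` has not yet been measured in this assay. Compound 3 differs from compound 2 by chloro in place of methoxy on an aromatic carbon. Going by the values given here, no measured pair shows this change, so the expected step from compound 2 to compound 3 is estimated at no change at the digits printed from compound 2 to compound 3 (within the scatter), nothing beyond the scatter in either direction. Compound 3 is therefore expected to give about 1500 nM in this assay, with a range from 600 nM to 4000 nM.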

Compound 3, concentration for 50% growth inhibition: 1650 nM
Compound 3: middle estimate off by 1.1-fold (0.04 log units), on the low side; measured number inside the range.
By their numbers in this assay, from the lowest: compounds 2, 3 and 1 (each within the scatter of the next).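

In this assay, chloro in place of methoxy on an aromatic carbon para to a large group gives a 1.1-fold higher number from compound 2 to compound 3 (0.04 log units; within the scatter), so the two groups cannot be told apart at this position. Going by these compounds alone, this is the first measured pair for this change, as compound 1 and compound 2 differ in more than one place. Nothing at hand bears on why the two groups read alike.

On these data alone, whether an amine or a carboxylic acid at this position would also stay within the scatter of compound 2 remains open. So does whether chloro and methoxy would read alike on another core.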